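Oxolan-2-yl in place of oxetan-3-yl: series notes

The source may report more compounds than this note shows. Statements on the series, on what has been measured and on what is new or still open speak of the compounds shown alone.

Measured in a physicochemical assay for solubility, read by chemiluminescence, measured as kinetic solubility; a higher number here means a more soluble compound, a lower number a less soluble compound:
- compound 1 `CC(=O)NCc1cccc(Cn2nc(NS(=O)(=O)c3ccc(Cl)s3)c3c(Cl)cccc32)c1`: >= 226 ug/mL (a limit)
- compound 2 `CC(=O)NCc1cccc(Cn2nc(NS(=O)(=O)c3ccc(Cl)s3)c3c(CO)cccc32)c1`: >= 113 ug/mL (a limit)
- compound 3 `COc1cccc2c1c(NS(=O)(=O)c1ccc(Cl)s1)nn2Cc1cccc(CNC(=O)C2COC2)c1`: >= 173 ug/mL (a limit)

Compound 3 has no exact reading, and its entry of >= 173 ug/mL is a limit. The other two entries are limits as well, so the three compounds cannot be placed in order.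

Compound 4 `COc1cccc2c1c(NS(=O)(=O)c1ccc(Cl)s1)nn2Cc1cccc(CNC(=O)C2CCCO2)c1` differs from compound 3 by one change: oxolan-2-yl in place of oxetan-3-yl on a carbonyl carbon. The amide and the rest of the structure stay the same.

For the measured compounds named here, only one measured step is available for comparison, a step that the two limits leave unreadable from compound 1 to compound 2 (hydroxymethyl in place of chloro on an aromatic carbon). It lies at a different place in the structure and offers no size to carry over. Going by the values given here, no measured step covers a change on this carbonyl carbon.

No shift beyond the usual scatter is therefore expected in this assay, and no direction is favoured. The expected change is an at least 1.0-fold lower number from compound 3 to compound 4 (0.00 log units; that floor lies within the scatter) and rests only on the limit for compound 3 of >= 173 ug/mL as an anchor. For compound 4 the estimate is 170 ug/mL, with an expected range of 90 ug/mL to 240 ug/mL, and another limit rather than a number would not be unexpected.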

Compound 4, solubility: >= 153 ug/mL
Compound 4 ended at the assay's limit; the forecaster's own chance of this, stated with the estimate: 75%; the middle value is on the limit's open side.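

In this assay compound 4 gives >= 153 ug/mL as a limit. For the compounds shown here, compound 3 gives >= 173 ug/mL as a limit too, so no step between compound 3 and compound 4 can be read. The compounds shown leave open whether oxolan-2-yl in place of oxetan-3-yl on a carbonyl carbon changes the read-out at all, and in which direction.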